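Isopropyl for Methyl on the Ring Nitrogen of Compound 3

The source may report more compounds than this note shows. Statements on the series, on what has been measured and on what is new or still open speak of the compounds shown alone.

Measured compounds:
Compound 1, `CC(C)c1ccn2ncnc(N[C@H]3CC[C@H](N(C)C)CC3)c12`: 1.3
Compound 2, `CN(C)[C@H]1CC[C@H](Nc2ncnn3ccc([C@H]4CC[C@H](C(N)=O)CC4)c23)CC1`: 0.2
Compound 3, `Cn1ccc2ncnc(N[C@H]3CC[C@H](N(C)C)CC3)c21`: -0.8

In a physicochemical assay for lipophilicity, using the shake flask method, at pH 7.4 (a lower number here means a more polar compound, a higher number a more lipophilic compound), compound 3 gives -0.8, the lowest of the three numbers; compound 2 stands a step above it and compound 1 furthest above it, both gaps beyond the scatter. Compound 4, `CC(C)n1ccc2ncnc(N[C@H]3CC[C@H](N(C)C)CC3)c21`, has not yet been measured. It differs from compound 3 in one place: isopropyl in place of methyl on an aromatic nitrogen.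

Going by the values given here, only one measured step exists, a number 1.10 log units lower from compound 1 to compound 2 (beyond the scatter), and it concerns a different change at a different place, so it bears on the present step only loosely. Compound 1 carries an isopropyl group and compound 3 a methyl group, but they differ in more than one place; compound 1 gives 1.3 and compound 3 gives -0.8, a gap that does not isolate the change. Going from methyl to isopropyl adds two carbons and nothing polar, so compound 4 is expected to lie higher than compound 3 in this assay, by a moderate step, a number 0.90 log units higher from compound 3 to compound 4 (beyond the scatter). The estimate for compound 4 is 0.1, within -0.5 to 0.7.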

Compound 4, distribution coefficient: 0.1
Beside the measured number, compound 4's estimate shows no gap at the digits printed, and the stated range covers the measured number.
By their numbers in this assay, from the lowest: compound 3; then compounds 4 and 2 (each within the scatter of the next); then compound 1.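

In this assay, the aromatic nitrogen of the five-membered ring proves responsive: isopropyl in place of methyl gives a number 0.90 log units higher from compound 3 to compound 4 (beyond the scatter). This is the only step shown at this nitrogen, and it adds carbon alone, with no hydrogen-bond donor or acceptor entering or leaving, whereas the earlier step, a number 1.10 log units lower from compound 1 to compound 2 (beyond the scatter), concerned a different change on an aromatic carbon of another core. Nothing available explains the size of the new step or says what lies behind it.

Going by these compounds, whether a longer chain such as n-butyl, a cyclopropyl ring, or a chain ending in an amine or a carboxylic acid would raise or lower the number at this nitrogen stays open. So does whether the same exchange of methyl for isopropyl would give a similar step on a different core.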